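This account rests on a few compounds, and the source may have more. Where it says the series, first, only, none or still open, it means among the compounds named here.

Working notes on the amide series built on the shared core of compound 3 `CCCNc1cc(NC(=O)c2ccncc2)cc(C(F)(F)F)c1`, followed in an assay on HEK293-TREx cells for antagonist activity at transient receptor potential cation channel subfamily A member 1 (Homo sapiens), read by calcium flux; a lower number here means a stronger inhibitor, a higher number a weaker inhibitor. Compound 3 gives 2600 nM, the higher of the two numbers recorded; the nearest is compound 2 `CCCNc1cc(NC(=O)c2cccnc2)cc(C(F)(F)F)c1` at 940 nM, and the step of a 2.8-fold higher number from compound 2 to compound 3 (0.44 log units; beyond the scatter) is modest but beyond the scatter. Compound 1 `CCCN(CCC)c1cc(NC(=O)c2cccs2)cc(C(F)(F)F)c1` sits at the limit of > 32000 nM in this assay, at which 1 of the 3 values shown sits, so for compound 1 only a limit, > 32000 nM, is known and no number.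

Compound 4 `CCCNc1cc(NC(=O)c2ccc(F)c(F)c2)cc(C(F)(F)F)c1` differs from compound 3 by 3,4-difluorophenyl in place of pyridin-4-yl on a carbonyl carbon. For the measured compounds named here, the single measured step at this position, a 2.8-fold higher number from compound 2 to compound 3 (0.44 log units; beyond the scatter), exchanges one pyridyl for the other and says nothing about a six-membered aromatic ring of carbon only carrying fluorine; no measured step bears directly on the change. With no guide in the data, the step from compound 3 to compound 4 is expected to be small, a 1.4-fold lower number from compound 3 to compound 4 (0.16 log units; within the scatter), in either direction and probably within the scatter. Compound 4 is therefore estimated at 1800 nM, with a range from 450 nM to 7000 nM.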

Compound 4, half-maximal inhibitory concentration: 1200 nM
Compound 4: the middle estimate sits 1.5-fold (0.18 log units) above what was measured; the range from low to high includes it.
By their numbers in this assay, from the lowest: compounds 2 and 4 (each within the scatter of the next); then compound 3. At a limit, above all of these: compound 1.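

A ring of carbon only carrying fluorine is accepted on the carbonyl carbon in this assay: a 2.2-fold lower number from compound 3 to compound 4 (0.34 log units; beyond the scatter) shows that a ring nitrogen is not needed for a number at this level. With a 1.3-fold higher number from compound 2 to compound 4 (0.11 log units; within the scatter), 3,4-difluorophenyl and pyridin-3-yl cannot be ordered, and pyridin-4-yl alone stands apart, with steps beyond the scatter to both. No measurement at hand accounts for these steps.

Compound 1 differs from the others in more than one place and its > 32000 nM is a limit, so the steps to it cannot be read. Open at this place are a single fluorine on the phenyl ring, a carboxylic acid or an amine on that ring, and a saturated ring such as piperidine.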